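A few compounds are considered here, and "the series" means these few. Any claim that something is new, unique, unknown or untested is made for them only; others in the source may bear on it.

Of the compounds shown here, three have been measured in a functional assay on the whole organism for antagonist activity, with Mus musculus as the target; a lower number here means that less compound is needed, a higher number that more compound is needed for the effect. Compound 1, `CC(C#CCn1ccnc1)N1CCCC1=O`, gives 3.7 mg/kg in this assay. Compound 2, `Cc1cncn1CC#CC(C)N1CCCC1=O`, differs from compound 1 by methyl in place of hydrogen on an aromatic carbon, and in this assay compound 2 gives 2.5 mg/kg; the step of a 1.5-fold lower number from compound 1 to compound 2 (0.17 log units; within the scatter) is small enough that the two values cannot be told apart. Compound 3, `CC1CCC(=O)N1CC#CCn1ccnc1`, is built from the same atoms as compound 1 joined differently; the difference between the two cores is not broken down here. In this assay compound 3 gives 1.1 mg/kg, the lowest number of the three, with both of its gaps to the other compounds beyond the usual scatter.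

Compound 4, `Cc1cncn1CC#CCN1C(=O)CCC1C`, has not yet been measured. It differs from compound 3 by methyl in place of hydrogen on an aromatic carbon, the same change as that between compound 1 and compound 2, at the same place on the ring. Because the earlier step was a 1.5-fold lower number from compound 1 to compound 2 (0.17 log units; within the scatter), the new step is expected to be about as small: a 1.4-fold lower number from compound 3 to compound 4 (0.14 log units; within the scatter). Compound 4 is therefore expected to give 0.8 mg/kg in this assay, with a likely range from 0.4 mg/kg to 1.8 mg/kg.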

Compound 4, dose for half-maximal effect: 1.4 mg/kg
The estimate for compound 4 lay 1.8-fold (0.24 log units) below the measured number, within the range that was stated.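

In this assay, methyl in place of hydrogen on an aromatic carbon gives a 1.3-fold higher number from compound 3 to compound 4 (0.10 log units; within the scatter), so the two values cannot be told apart. Set beside the same change on the other core, the two steps cannot be separated either, and the small effect of the methyl carries over between these cores as far as this assay can tell: the same change on two cores in this assay, a 1.5-fold lower number (0.17 log units; within the scatter) from compound 1 to compound 2 and a 1.3-fold higher number (0.10 log units; within the scatter) from compound 3 to compound 4, 1.9-fold (0.27 log units) apart, within the scatter of two such steps. This does not show that the methyl has no effect at all, since a small real effect could be hidden in the scatter, and two pairs of compounds say nothing about how the change would behave on a further core.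

The compounds shown carry only hydrogen or methyl on this aromatic carbon, so it remains open whether an ethyl group, a longer chain, an amine or a carboxylic acid there would move the number beyond the scatter. Also open, as far as these compounds go, is whether a methyl on the other aromatic carbons of the five-membered ring would give a similarly small step.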